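Replacing Oxan-4-yl on the Carbonyl of Compound 1

The source may hold more compounds than are shown below. What is called first, only, known or untested is meant among the compounds shown, and "the series" means these compounds.

Going by the values given here, in a physicochemical assay for solubility, read by mass spectrometry, in phosphate buffer, with a stated time of 24 h, at pH 7.4 (a higher number here means a more soluble compound, a lower number a less soluble compound), compound 1 (`O=C(Nc1ccc(OC(F)(F)F)cc1)NC1CCN(C(=O)C2CCOCC2)CC1`) gives 91 ug/mL and stands highest of the two numbers so far. In this assay compound 2 (`CC[C@H](C)C(=O)N1CCC(CC(=O)Nc2ccc(OC(F)(F)F)c(F)c2)CC1`) gives 21 ug/mL and that gap lies beyond the scatter. Compound 3 (`Cc1occc1C(=O)N1CCC(NC(=O)Nc2ccc(OC(F)(F)F)cc2)CC1`) keeps the core of compound 1 but carries 2-methylfuran-3-yl in place of oxan-4-yl on a carbonyl carbon. Among the compounds with values here, no measured pair shows this change, so the expectation is a loose one. The expected step in this assay is a fall beyond the scatter (a 2.6-fold lower number from compound 1 to compound 3 (0.41 log units; beyond the scatter)). Compound 3 is estimated at 35 ug/mL (expected range 10 ug/mL to 90 ug/mL).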

Compound 3, solubility: 8.6 ug/mL
The estimate for compound 3 lay 4.1-fold (0.61 log units) above the measured number; measured number outside the range, below it.
By their numbers in this assay, from the lowest: compound 3; then compound 2; then compound 1.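

In this assay, placing 2-methylfuran-3-yl in place of oxan-4-yl on the carbonyl carbon gives an 11-fold lower number from compound 1 to compound 3 (1.02 log units; beyond the scatter) and shows that this position is sensitive to the group it carries. The two groups have the same counts of heavy atoms, donors and acceptors and no net charge, but one ring is six-membered and non-aromatic and the other five-membered and aromatic. Nothing given here explains the step. Ring size and aromatic character remain unseparated in this single change. As far as these compounds go, how an unsubstituted furan, a saturated five-membered ring or an amine-bearing chain would read on this carbonyl stays open.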